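A few compounds are considered here, and "the series" means these few. Any claim that something is new, unique, unknown or untested is made for them only; others in the source may bear on it.

Measured in a functional assay on A2780 cells (Homo sapiens) for antiproliferative activity, read by MTT assay, with a stated time of 48 h; on this read-out higher numbers stand for weaker inhibition and lower numbers for stronger inhibition:
- Compound 1 `COc1ccc(-c2nc3cnccc3n2-c2cc(OC)c(OC)c(OC)c2)cc1O`: > 20000 nM
- Compound 2 `COc1ccc(-c2cc3c(cn2)[nH]c(=O)n3-c2cc(OC)c(OC)c(OC)c2)cc1O`: 240 nM

The entry for compound 1 is a limit of the assay and not a number. Among the measured compounds shown here, compound 2, at 240 nM, holds the only true number so far. Compound 3 `COc1ccc(-c2cc3c(cn2)[nH]c(=O)n3-c2cc(OC)c(OC)c(OC)c2)cc1C(=O)O` keeps the core of compound 2 but has carboxy in place of hydroxy on an aromatic carbon, ortho to a methoxy group: carboxy in place of hydroxy on an aromatic carbon. For the measured compounds named here, no measured pair shows this change, so the expectation is only a judgement. The estimated change is a 21-fold higher number from compound 2 to compound 3 (1.32 log units; beyond the scatter), a large weakening in this assay, beyond the usual scatter. For compound 3 the expected value is 5000 nM, with an estimated range of 800 nM to 20000 nM.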

Compound 3, half-maximal inhibitory concentration: 4120 nM
Compound 3: the middle estimate sits 1.2-fold (0.08 log units) above what was measured, within the range that was stated.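

Among the compounds shown here, this is the first step at this position with a true number on both sides: carboxy in place of hydroxy gives a 17-fold higher number from compound 2 to compound 3 (1.23 log units; beyond the scatter) in this assay. The change weakens the compound strongly, yet compound 3 still gives a true number. Compound 1 alone stands at a limit, which is not a number: the limit of > 20000 nM in this assay, at which 1 of the 3 values shown sits.

Going by these compounds, how an amine or a methyl ester would fare at this position stays open. A single step also cannot tell why the carboxy group costs so much here.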